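The compounds below may be only part of what the source reports. "The series", "measured", "known", "first", "only" and "open" are said of these compounds alone.

Measured so far in an ADME assay on Vero cells (Chlorocebus sabaeus) for cytotoxicity, read by MTT assay, with a stated time of 72 h; on this read-out lower numbers stand for higher toxicity in this test and higher numbers for lower toxicity in this test:
compound 1, `COc1ccc(-c2cc(-c3ccc(C4NC(=O)c5ccccc5N4)cc3)nc(N)n2)cc1`, gives 124000 nM
compound 3, `CN1CCN(c2ccc(-c3cc(-c4ccc(C5NC(=O)c6ccccc6N5)cc4)nc(N)n3)cc2)CC1`, gives 8320 nM
compound 2, `CC1(c2ccc(NC(c3ccc(F)cc3)c3nnnn3C(C)(C)C)cc2)NC(=O)c2ccccc2N1`, gives "not determined" (no result reported) in this assay, that is, no result

For the measured compounds named here, only one step links measured compounds: a 15-fold lower number from compound 1 to compound 3 (1.17 log units; beyond the scatter). It concerns the core shared by compounds 1 and 3, a core that compound 2 does not carry, so it says nothing directly about the tetrazole series. Compound 2 stands nowhere on the numbers: its result in this assay was not determined, so there is no starting value for the step that follows.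

Compound 4, `CC1(c2ccc(NC(c3ccc(Br)cc3)c3nnnn3C(C)(C)C)cc2)NC(=O)c2ccccc2N1`, differs from compound 2 by bromo in place of fluoro on an aromatic carbon. Going by the values given here, no measured step bears on this exchange; neither the halogen change nor the core of compound 2 appears among the measured pairs. No direction is therefore expected beyond the scatter, and any estimate for compound 4 in this assay has to rest on the general range seen for compounds 1 and 3 rather than on a step. On that basis compound 4 is expected to give about 60000 nM, with a wide range from 10000 nM to 200000 nM, and a fair chance that only a limit is reported.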

Compound 4, half-maximal cytotoxic concentration: > 400000 nM
Compound 4 was reported as a limit; the forecaster's own chance of this, stated with the estimate: 35%; middle value at least 6.6-fold (0.82 log units) away from the limit.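

In this assay compound 4 gives > 400000 nM, which is a limit and not a number. Compound 2 has no result there, so no step can be read between compound 2 and compound 4. Still open, going by these compounds, is whether bromo in place of fluoro shifts this read-out at all on the core of compound 2.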